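The source may hold more compounds than are shown below. What is called first, only, known or untested is meant among the compounds shown, and "the series" means these compounds.

In a functional assay on A549 cells (Homo sapiens) for antiproliferative activity, read by CCK-8 assay, with a stated time of 72 h (a lower number here means a stronger inhibitor, a higher number a weaker inhibitor), compound 1 `CCOc1cc(C(C)(C)C)ccc1C1=NC(c2ccc(Cl)cc2)C(c2ccc(Cl)cc2)N1C(=O)NCCCCCCCC(=O)Nc1ccccc1N` gives 15200 nM and compound 2 `CCOc1cc(C(C)(C)C)ccc1C1=NC(c2ccc(Cl)cc2)C(c2ccc(Cl)cc2)N1C(=O)N1CCN(CCCCCC(=O)NO)CC1` gives 2910 nM. Compound 2 holds the lower of the two numbers, and the gap lies beyond the usual scatter. Compound 3 `CCOc1cc(C(C)(C)C)ccc1C1=NC(c2ccc(Cl)cc2)C(c2ccc(Cl)cc2)N1C(=O)N1CCN(Cc2ccc(C(=O)NO)cc2)CC1` departs from compound 2 in one place: 4-(hydroxycarbamoyl)phenyl in place of 4-(hydroxycarbamoyl)butyl on a saturated chain carbon bound to an amine nitrogen in a ring. Here 4-(hydroxycarbamoyl)phenyl stands in place of 4-(hydroxycarbamoyl)butyl on a saturated chain carbon bound to an amine nitrogen in a ring. Going by the values given here, no measured pair isolates this change, so no shift beyond the scatter is expected in this assay, in either direction. The expected change is a 1.1-fold lower number from compound 2 to compound 3 (0.05 log units; within the scatter). For compound 3 the estimated value is 2600 nM, with an expected range of 900 nM to 8000 nM.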

Compound 3, half-maximal inhibitory concentration: 2170 nM
Estimate against measurement, compound 3: 1.2-fold (0.08 log units) above; the measured number falls inside the stated range.
By their numbers in this assay, from the lowest: compounds 3 and 2 (each within the scatter of the next); then compound 1.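

In this assay, 4-(hydroxycarbamoyl)phenyl in place of 4-(hydroxycarbamoyl)butyl on a saturated chain carbon bound to an amine nitrogen in a ring gives a 1.3-fold lower number from compound 2 to compound 3 (0.13 log units; within the scatter). At this position, then, an open chain and a six-membered aromatic ring carrying the same hydroxycarbamoyl group cannot be told apart by this read-out. Nothing measured here bears on why the two groups read alike. Open, on these data alone, is whether a longer chain ending in hydroxycarbamoyl would read the same. Also open, as far as these compounds go, is whether a carboxylic acid could stand in place of the hydroxycarbamoyl group on either linker.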